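Acyl variation on a chlorophenylpiperidine amide series

A few compounds are considered here, and "the series" means these few. Any claim that something is new, unique, unknown or untested is made for them only; others in the source may bear on it.

Three amides built on the shared core have been measured. In an assay on THP-1 cells for displacement of a labelled ligand from C-C chemokine receptor type 1 (Homo sapiens) (on this read-out higher numbers stand for weaker inhibition and lower numbers for stronger inhibition), compound 1 `CC(C)[C@@H](NC(=O)c1cc2ccccc2s1)C(=O)N1CCC(c2ccc(Cl)cc2)CC1` gives 58 nM, the lowest of the three numbers. Compound 3 `CC[C@@H](C)[C@@H](NC(=O)CCc1ccccc1)C(=O)N1CCC(c2ccc(Cl)cc2)CC1` gives 66 nM in this assay, a number that sits within the usual scatter of that of compound 1, so no order between the two can be claimed. Compound 2 `O=C(N[C@@H](C(=O)N1CCC(c2ccc(Cl)cc2)CC1)C1CCCCC1)c1ccccc1` gives 121 nM in this assay, which lies beyond the scatter from compound 1.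

Compound 4 `CC(C)[C@@H](NC(=O)CCCc1ccccc1)C(=O)N1CCC(c2ccc(Cl)cc2)CC1` has not yet been measured. It differs from compound 1 in one place: 3-phenylpropyl in place of 1-benzothiophen-2-yl on a carbonyl carbon. Among the measured compounds shown here, no pair of measured compounds differs by exactly this change, so the size of the step has to be guessed. For the measured compounds named here, the only guide is compound 3, whose acyl part is also not 1-benzothiophen-2-yl and which gives 66 nM in this assay, close to compound 1. On that basis the step is expected to be small: a modest move towards a higher number, at most near the edge of the scatter, with the expected step written as a 1.6-fold higher number from compound 1 to compound 4 (0.19 log units; within the scatter). Compound 4 is therefore estimated at 90 nM in this assay, with a range from 40 nM to 200 nM.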

Compound 4, half-maximal inhibitory concentration: 95 nM
For compound 4 the middle estimate is 1.1-fold (0.02 log units) below the measured one; the range from low to high includes it.
By their numbers in this assay, from the lowest: compounds 1, 3, 4 and 2 (each within the scatter of the next, the first and the last beyond it).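

In this assay, among the compounds shown here, the step of a 1.6-fold higher number from compound 1 to compound 4 (0.21 log units; within the scatter) gives the first direct reading at this position. The rest of compound 1 is held fixed while only the group on the carbonyl carbon changes. The exchange keeps the six-membered aromatic ring of carbon only and the heavy-atom count of the group, but it removes the sulfur and the five-membered aromatic ring and replaces the fused ring system with an open three-carbon chain ending in phenyl. This pair therefore shows that, on this core, neither the sulfur nor the five-membered aromatic ring is required to stay within the scatter of compound 1, and no measured property of the two groups is available to explain the result.

For the compounds shown here, the single step cannot separate the loss of the sulfur from the loss of the fused ring, so the contribution of each remains unresolved. Also open, as far as these compounds go, is how this position would respond to a longer chain such as 4-phenylbutyl, or to an amine or a carboxylic acid on the chain in place of the terminal phenyl.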